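The source may report more compounds than this note shows. Statements on the series, on what has been measured and on what is new or still open speak of the compounds shown alone.

Measured so far in a functional assay on A549 cells (Homo sapiens) for cytotoxicity, read by MTT assay, with a stated time of 72 h; on this read-out higher numbers stand for weaker inhibition and lower numbers for stronger inhibition:
compound 1, `COc1cccc(/C=C2\CCC/C(=C\c3ccc(Cl)cc3)C2=O)c1OC`, gives only the assay limit > 20000 nM.
compound 2, `COc1cccc(/C=C2\CCC/C(=C\c3cccc(Br)c3)C2=O)c1OC`, gives only the assay limit > 20000 nM.
compound 3, `COc1ccccc1/C=C1\CCC/C(=C\c2cccc(OC)c2OC)C1=O`, gives only the assay limit > 20000 nM.

Compound 3 therefore stands nowhere on a numerical scale in this assay: its value is a limit, and so are the other two shown, as recorded in the limit of > 20000 nM in this assay, at which 3 of the 3 values shown sit. The three steps that connect the measured compounds, a step that the two limits leave unreadable from compound 1 to compound 2, a step that the two limits leave unreadable from compound 1 to compound 3 and a step that the two limits leave unreadable from compound 2 to compound 3, are each unreadable in size, since both ends sit at the limit; none of them tells how much a change of the aryl group on the double-bonded chain carbon shifts the read-out.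

Compound 4, `COc1cccc(/C=C2\CCC/C(=C\c3ccc(Cl)cc3Cl)C2=O)c1OC`, is the next member, differing from compound 3 by 2,4-dichlorophenyl in place of 2-methoxyphenyl on a double-bonded chain carbon bound to a double-bonded ring carbon. All three measured steps bear on it in kind, as exchanges of the same aryl group, but none gives a readable magnitude or direction. With every recorded value at the limit, the expectation for compound 4 in this assay is a further limit rather than a number, and a step that the limit leaves unreadable from compound 3 to compound 4 is estimated only nominally. Compound 4 is expected at 25000 nM, in the range 8000 nM to 80000 nM.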

Compound 4, half-maximal inhibitory concentration: > 20000 nM
Compound 4 gave a limit, no number; the forecaster's own chance of this, stated with the estimate: 70%; the middle value does not contradict the limit.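

In this assay compound 4 gives > 20000 nM, a limit and not a number. No new step can be read, as the steps linking compound 4 to compound 1, compound 2 and compound 3 have limits at both ends: the limit of > 20000 nM in this assay, at which 4 of the 4 values shown sit.

The compounds shown leave open whether any of these aryl exchanges moves the read-out, in which direction and how far.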